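The source may report more compounds than this note shows. Statements on the series, on what has been measured and on what is new or still open speak of the compounds shown alone.

Compound 1, `Cc1nc2c(C[S+]([O-])c3ccccc3)cccn2c1C`: 42%
Compound 2, `[C-]#[N+]Cc1c(C)nc2c(OCc3ccccc3)cccn12`: 96%

In a functional assay on the whole organism with Rattus norvegicus as the target, with a stated time of 4 h, at a dose of 40 mg/kg by the intraperitoneal route (a higher number here means more inhibition at the dose given (going by the name of the read-out), a lower number less inhibition), compound 2 gives 96%, the higher of the two numbers; compound 1 gives 42%, a value lower by an amount beyond the usual scatter. The two measured compounds differ in more than one place, so their gap cannot be tied to any single change.

Compound 3, `Cc1nc2c(OCc3ccccc3)cccn2c1Cl`, has not yet been measured. It is related to compound 2 through (one chlorine atom in place of a group of 3 heavy atoms (2 carbon, 1 nitrogen; no ring), on an aromatic carbon). Among the measured compounds shown here, no measured pair shows the effect of this exchange, so the expectation for compound 3 rests on compound 2 alone. Because compound 2 gives 96%, there is little room upward, and the expected step is downward: a number 31 percentage points lower from compound 2 to compound 3 (beyond the scatter) is the estimated change, of moderate size, with wide uncertainty. Compound 3 is expected to give about 65% in this assay, within a range from 30% to 95%.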

Compound 3, a percentage reported as inhibition, in the whole organism at one dose (the size of the read-out at that dose, not a potency): 93%
Compound 3: the middle estimate sits 28 percentage points below what was measured, and the stated range covers the measured number.
By their numbers in this assay, from the lowest: compound 1; then compounds 3 and 2 (each within the scatter of the next).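

On the aromatic carbon of the five-membered aromatic ring, chloro in place of the group of 3 heavy atoms (2 carbon, 1 nitrogen) gives, in this assay, a number 3 percentage points lower from compound 2 to compound 3 (within the scatter). This single exchange therefore makes no difference beyond the scatter, and in this pair the high read-out does not depend on the triple bond of the group that leaves, since a lone chlorine atom serves as well. No measurement is at hand that would explain why the two groups can be exchanged in this way.

The compounds shown leave open whether an amine or a carboxylic acid on this same carbon would also keep the read-out high. Both numbers also come from a single dose, so any difference in potency between compound 2 and compound 3 remains unseen.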